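From (methylsulfonyl)methyl to dimethylsulfamoyl on the shared core

A few compounds are considered here, and "the series" means these few. Any claim that something is new, unique, unknown or untested is made for them only; others in the source may bear on it.

Measured in an in vitro ADME assay on microsomes from liver (Homo sapiens) for metabolic stability, tested at 5 uM; a higher number here means that the compound lasts longer, a lower number that the compound disappears faster:
Compound 1 `CC(C)CCn1nc(-c2cccs2)c(O)c(C2=NS(=O)(=O)c3cc(NS(=O)(=O)C4CC4)ccc3N2)c1=O`: > 1 h (a limit)
Compound 2 `CC(C)CCn1nc(-c2cccs2)c(O)c(C2=NS(=O)(=O)c3cc(CS(C)(=O)=O)ccc3N2)c1=O`: 0.467 h

Only compound 2 gives an actual number, 0.467 h. The value of compound 1, > 1 h, is a limit. Compound 3 `CC(C)CCn1nc(-c2cccs2)c(O)c(C2=NS(=O)(=O)c3cc(S(=O)(=O)N(C)C)ccc3N2)c1=O` carries dimethylsulfamoyl in place of (methylsulfonyl)methyl on an aromatic carbon. Among the measured compounds shown here, one measured step bears on this change, as it alters the group on that same aromatic carbon: an at least 2.1-fold lower number from compound 1 to compound 2 (0.33 log units; beyond the scatter). It is a single step with a different group, so only a small change is expected, within the scatter. The expected step is a 1.3-fold higher number from compound 2 to compound 3 (0.11 log units; within the scatter). Compound 3 is estimated at 0.6 h, with an expected range from 0.3 h to 1.2 h.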

Compound 3, half-life: 0.183 h
The estimate for compound 3 lay 3.3-fold (0.52 log units) above the measured number; the measured number lies below the stated range.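

In this assay, this aromatic carbon proves sensitive even to a swap between two groups that both lack a ring and hydrogen-bond donors: the change gives a 2.6-fold lower number from compound 2 to compound 3 (0.41 log units; beyond the scatter). Against (cyclopropylsulfonyl)amino, dimethylsulfamoyl gives an at least 5.4-fold lower number from compound 1 to compound 3 (0.73 log units; beyond the scatter), so the three groups now fall in one order, with every step beyond the scatter. The value of compound 1 is a limit, not a number: the limit of > 1 h in this assay, at which 1 of the 3 values shown sits.

From the compounds shown here alone, how far compound 1 truly lies from the other two remains open. So does what a simple amine or a carboxylic acid on this aromatic carbon would give.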